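Nitro to methoxy in a weakly cytotoxic series

This account rests on a few compounds, and the source may have more. Where it says the series, first, only, none or still open, it means among the compounds named here.

Compound 1 `COc1cc(-n2c(-c3ccccc3)cn(C(C)=O)c2=O)cc(OC)c1OC` gives > 50000 nM as a limit
Compound 2 `COc1cc(-n2c(-c3ccc([N+](=O)[O-])cc3)cn(C(C)=O)c2=O)cc(OC)c1OC` gives 49600 nM as a number

In a functional assay on A549 cells (Homo sapiens) for cytotoxicity, read by MTT assay, with a stated time of 48 h (a higher number here means a weaker inhibitor, a lower number a stronger inhibitor), compound 2 holds the only number shown, and the value of compound 1 is a limit. Compound 3 `COc1ccc(-c2cn(C(C)=O)c(=O)n2-c2cc(OC)c(OC)c(OC)c2)cc1` differs from compound 2 by methoxy in place of nitro on an aromatic carbon in all, with methoxy in place of nitro on an aromatic carbon. Within the data shown here, the only measured step bearing on this reads a number no higher from compound 1 to compound 2 (the limit leaves the size open) and gives no usable size. No step beyond the scatter can therefore be firmly expected in this assay and no direction is indicated. The expected step is a 1.7-fold lower number from compound 2 to compound 3 (0.22 log units; within the scatter) in this estimate. For compound 3 the estimated value is 30000 nM with an expected range from 2000 nM to 50000 nM in all.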

Compound 3, half-maximal inhibitory concentration: 17800 nM
Beside the measured number, compound 3's estimate is 1.7-fold (0.23 log units) above it, within the range that was stated.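

In this assay, the group at this position on the aromatic ring now makes a difference of readable size: methoxy in place of nitro gives a 2.8-fold lower number from compound 2 to compound 3 (0.45 log units; beyond the scatter). Methoxy in place of hydrogen gives an at least 2.8-fold lower number from compound 1 to compound 3 (0.44 log units; beyond the scatter), so compound 3 holds the lowest number of the three. The full size of that second step stays open because the value of compound 1 is a limit: the limit of > 50000 nM in this assay, at which 1 of the 3 values shown sits.

As far as these compounds go, whether an amine, a hydroxyl or a longer alkoxy chain at this position would lower the number further remains open. So does whether methoxy would act alike elsewhere on this aromatic ring.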